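Fluorine in Place of a Methoxy Group on the Ring

The source may hold more compounds than are shown below. What is called first, only, known or untested is meant among the compounds shown, and "the series" means these compounds.

Compound 1 `COc1ccc(OCC2=NCCO2)cc1` stands lowest of three compounds in a toxicity assay on the whole organism with Rattus norvegicus as the target, at a dose of 400 mg/kg by the oral route; on this read-out lower numbers stand for a weaker effect and higher numbers for a stronger effect at the one dose given: compound 1 gives 15%, while compound 2 `Brc1ccccc1OCC1=NCCO1` gives 40% and compound 3 `Clc1ccccc1OCC1=NCCO1` gives 80%. Compound 4 `Fc1ccc(OCC2=NCCO2)cc1` differs from compound 1 by fluoro in place of methoxy on an aromatic carbon. Among the measured compounds shown here, the only measured step, a swap of one halogen for another, gave a number 40 percentage points higher from compound 2 to compound 3 (beyond the scatter); it concerns a different position and a different pair of groups, so it bears only loosely on the present change. Both halogen-bearing compounds, 2 and 3, sit above compound 1, which hints that a fluorine on the ring may also lift the number, though a single pair is thin evidence. Compound 4 is therefore expected to give 40%, within a range from 15% to 70%, an estimated step of a number 25 percentage points higher from compound 1 to compound 4 (beyond the scatter).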

Compound 4, a percentage reported as activity, at one dose (the size of the read-out at that dose, not a potency): 75%
Compound 4: the middle estimate sits 35 percentage points below what was measured; the whole stated range lies below it.
By their numbers in this assay, from the lowest: compound 1; then compound 2; then compounds 4 and 3 (each within the scatter of the next).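

In this assay, fluoro in place of methoxy on this aromatic carbon gives a number 60 percentage points higher from compound 1 to compound 4 (beyond the scatter). The earlier step showed only one halogen exchanged for another at a different place; this pair shows that the group para to a group of 7 heavy atoms can strongly shift the read-out with the rest of the molecule unchanged. Nothing measured here accounts for the size of this step. Still open, on these data alone, is whether other groups at this place, such as an amine or a carboxylic acid, would move the number as far.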